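Methyl to Nitro on a Benzyl Group: Weak Inhibitors

The compounds below may be only part of what the source reports. "The series", "measured", "known", "first", "only" and "open" are said of these compounds alone.

Two measured compounds share one core and differ only in the benzyl group attached to the amine nitrogen of the ring. Compound 1 `COC(=O)c1ccc(C2SCC(=O)N2c2ccc(N3CCN(Cc4cc(OC)c(OC)c(OC)c4)CC3)cn2)c(OC)c1` carries a 3,4,5-trimethoxyphenyl there. In a functional assay on K562 cells (Homo sapiens) for antiproliferative activity, read by MTT assay and trypan blue exclusion, with a stated time of 72 h (a lower number here means a stronger inhibitor, a higher number a weaker inhibitor), compound 1 gives only a limit of the assay, > 100000 nM. Compound 2 `COC(=O)c1ccc(C2SCC(=O)N2c2ccc(N3CCN(Cc4cccc(C)c4)CC3)cn2)c(OC)c1` carries a 3-methylphenyl instead. In this assay compound 2 also gives only a limit, > 100000 nM. The step that the two limits leave unreadable from compound 1 to compound 2 therefore cannot be read, and both values sit at the limit of > 100000 nM in this assay, at which 2 of the 2 values shown sit.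

Compound 3 `COC(=O)c1ccc(C2SCC(=O)N2c2ccc(N3CCN(Cc4cccc([N+](=O)[O-])c4)CC3)cn2)c(OC)c1` is not yet measured. It differs from compound 2 by nitro in place of methyl on an aromatic carbon; read one bond further out, 3-methylbenzyl becomes 3-nitrobenzyl. No measured step bears on this change: the only step shown has no readable size, and both measured compounds sit at the same limit. There is thus no basis for expecting movement beyond the scatter in either direction in this assay.

For compound 3 the expected outcome is another limit, estimated as 150000 nM with a range from 50000 nM to 500000 nM. The estimated step is a step that the limit leaves unreadable from compound 2 to compound 3.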

Compound 3, half-maximal inhibitory concentration: 68700 nM
Estimate against measurement, compound 3: 2.2-fold (0.34 log units) above, within the range that was stated.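

In this assay, among the compounds shown here, compound 3 is the first of the three to give an actual number rather than a limit, so a change on this benzyl ring, at the place meta to a large group, has now produced a readable value. As far as these compounds go, replacing methyl with nitro gives an at least 1.4-fold lower number from compound 2 to compound 3 (0.16 log units; that floor lies within the scatter), and replacing 3,4,5-trimethoxyphenyl with 3-nitrophenyl gives an at least 1.4-fold lower number from compound 1 to compound 3 (0.16 log units; that floor lies within the scatter); each of these is only a floor, so the true size of either step remains unknown and could be larger. The step between the two earlier compounds still cannot be read, and they offer no number to set against this one: the limit of > 100000 nM in this assay, at which 2 of the 3 values shown sit.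

The compounds shown leave open whether this readable value is particular to nitro or would also appear with another group at the same place, such as a nitrile or an amine. From the compounds shown here alone, a single number also cannot show a trend, so it remains open whether any group on this ring could bring the series far below the values seen so far.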